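From bromo to hydroxy on the way to compound 3

A few compounds are considered here, and "the series" means these few. Any claim that something is new, unique, unknown or untested is made for them only; others in the source may bear on it.

Measured in a functional assay on HCT-116 cells (Homo sapiens) for inhibition, read by CCK-8 assay, with a stated time of 48 h; a lower number here means a stronger inhibitor, a higher number a weaker inhibitor:
compound 1 `COc1cc(N(Cc2ccc(C)cc2)C(=O)CSC(=S)N2CCN(C(=O)OC(C)(C)C)CC2)cc(OC)c1OC`: > 20000 nM
compound 2 `COc1ccc(CN(C(=O)CSC(=S)N2CCN(C(=O)OC(C)(C)C)CC2)c2cc(OC)c(OC)c(OC)c2)cc1Br`: 9710 nM

Compound 1 reads > 20000 nM, which is a limit of the assay and not a number. Among the compounds with values here, that leaves compound 2, at 9710 nM, with the only true number so far in this assay.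

Compound 3 `COc1ccc(CN(C(=O)CSC(=S)N2CCN(C(=O)OC(C)(C)C)CC2)c2cc(OC)c(OC)c(OC)c2)cc1O` differs from compound 2 in one group, with hydroxy in place of bromo on an aromatic carbon. Within the data shown here, one measured step bears on this part of the molecule: an at least 2.0-fold lower number from compound 1 to compound 2 (0.31 log units; beyond the scatter). This step lies beyond the scatter and replaced 4-methylphenyl with 3-bromo-4-methoxyphenyl, so it shows that changes here can move the number. Among the measured compounds shown here, no measured compound carries the hydroxy group, so the direction is uncertain. The expected change is modest, towards a lower number: a 1.9-fold lower number from compound 2 to compound 3 (0.29 log units; within the scatter). Compound 3 is estimated at 5000 nM, within an expected range of 800 nM to 20000 nM.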

Compound 3, half-maximal inhibitory concentration: 128 nM
Compound 3: the middle estimate sits 39-fold (1.59 log units) above what was measured; the whole stated range lies above it.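

Within the data shown here, the earlier step showed only that exchanging the whole group on this chain carbon could move the number. In this assay, replacing one bromo with one hydroxy, ortho to a methoxy group, gives a 76-fold lower number from compound 2 to compound 3 (1.88 log units; beyond the scatter) with the rest of the molecule unchanged, so this single aromatic position matters greatly. Changing the whole group from 4-methylphenyl to 3-hydroxy-4-methoxyphenyl gives an at least 150-fold lower number from compound 1 to compound 3 (2.19 log units; beyond the scatter) and marks the full span seen so far. That span is only a minimum, since compound 1 stands at a limit and not a number: the limit of > 20000 nM in this assay, at which 1 of the 3 values shown sits.

As far as these compounds go, whether the hydroxy group's hydrogen-bond donor is what matters stays open, and a second methoxy group at this position would help to test it. From the compounds shown here alone, how an amine or a carboxylic acid would fare at this position also remains unknown.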